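The compounds below may be only part of what the source reports. "The series", "measured", "known", "first", "only" and "open" are said of these compounds alone.

Measured compounds:
- compound 1, `CC1=C(C(=O)OC(C)(C)C)C(c2cccs2)NC(=O)N1`: 7%
- compound 2, `CC1=C(C(=O)OCC2CC2)C(c2ccoc2)NC(=O)N1`: 3%
- compound 3, `CCC(CC)OC(=O)C1=C(C)NC(=O)NC1c1cccs1`: 1%

In an assay on membranes from HeLa cells for displacement of a labelled ligand from adenosine receptor A3 (Homo sapiens), read by scintillation counting, with a stated time of 180 min, tested at 1 uM (on this read-out lower numbers stand for less inhibition and higher numbers for more inhibition at the one concentration tested (going by the name of the read-out)), compound 1 gives 7%, compound 2 gives 3% and compound 3 gives 1%. Compound 3 carries the lowest of the three numbers, yet its gaps to compound 2 and to compound 1 are both within the scatter, so the three compounds cannot be told apart on these readings. Among the measured compounds shown here, the only single-place step measured, a number 6 percentage points lower from compound 1 to compound 3 (within the scatter), is within the scatter as well.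

Compound 4, `CC1=C(C(=O)OCC2CC2)C(c2cccs2)NC(=O)N1`, follows from compound 3 by one change: cyclopropylmethyl in place of pentan-3-yl on an oxygen next to a carbonyl group. The step from compound 1 to compound 3, which exchanged groups at the same oxygen next to a carbonyl group, bears on it and was within the scatter. Compound 2 carries the entering cyclopropylmethyl group and gives 3%. All three measured values are low and indistinguishable, so no step beyond the scatter is expected in this assay for the change to compound 4; the expected step is a number 2 percentage points higher from compound 3 to compound 4 (within the scatter). Compound 4 is therefore estimated at 3%, within 0% to 12%.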

Compound 4, a percentage reported as inhibition, at one concentration (the size of the read-out at that concentration, not a potency): 1%
For compound 4 the middle estimate is 2 percentage points above the measured one, and the stated range covers the measured number.
By their numbers in this assay, from the lowest: compounds 3, 4, 2 and 1 (each within the scatter of the next).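

On an oxygen next to a carbonyl group, cyclopropylmethyl in place of pentan-3-yl gives no change at the digits printed from compound 3 to compound 4 (within the scatter) in this assay and cyclopropylmethyl in place of tert-butyl gives a number 6 percentage points lower from compound 1 to compound 4 (within the scatter) in the same read-out, so these three groups cannot be told apart at this position. With cyclopropylmethyl held fixed, the first step measured on the saturated ring carbon, thiophen-2-yl in place of furan-3-yl, gives a number 2 percentage points lower from compound 2 to compound 4 (within the scatter) and separates neither group from the other. No measurement on hand offers an explanation for these readings.

All readings come from one concentration, so it stays open whether any of these compounds differ in potency. From the compounds shown here alone, what a longer chain ending in an amine on that oxygen, or a phenyl on the saturated ring carbon, would give also stays open.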